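Aryl Against Alkyl on the Alkyne of Compound 3

This account rests on a few compounds, and the source may have more. Where it says the series, first, only, none or still open, it means among the compounds named here.

The measured compounds and their values:
compound 1, `Cc1ccc(C#Cc2cn(C/C=C\CN3C(=O)c4ccccc4C3=O)c(=O)[nH]c2=O)cc1` — > 100000 nM
compound 2, `CCCCCc1ccc(C#Cc2cn(C/C=C\CN3C(=O)c4ccccc4C3=O)c(=O)[nH]c2=O)cc1` — > 100000 nM
compound 3, `CCCCC#Cc1cn(C/C=C\CN2C(=O)c3ccccc3C2=O)c(=O)[nH]c1=O` — 82000 nM

Three compounds share one core and differ only in the group on the triple-bonded carbon. Going by the values given here, in a functional assay on SW-620 cells (Homo sapiens) for antiproliferative activity, read by MTT assay, with a stated time of 3 days (on this read-out higher numbers stand for weaker inhibition and lower numbers for stronger inhibition), compound 3 gives 82000 nM, the only true number among the three. For compound 1 the value is a limit of the assay, > 100000 nM. For compound 2 the value is also a limit, > 100000 nM. Two of the three results thus sit at the limit of > 100000 nM in this assay, at which 2 of the 3 values shown sit, so compound 3 stands as the one whose inhibition could be measured at all.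

Compound 4, `CCCCc1ccc(C#Cc2cn(C/C=C\CN3C(=O)c4ccccc4C3=O)c(=O)[nH]c2=O)cc1`, has not yet been measured. It differs from compound 3 by 4-butylphenyl in place of butyl on a triple-bonded carbon. Among the compounds with values here, the steps that bear on this change run the other way: an at least 1.2-fold lower number from compound 1 to compound 3 (0.08 log units; that floor lies within the scatter) and an at least 1.2-fold lower number from compound 2 to compound 3 (0.08 log units; that floor lies within the scatter), each only a floor because compounds 1 and 2 sit at a limit. The step that the two limits leave unreadable from compound 1 to compound 2 shows nothing readable about chain length on the phenyl ring. Putting a 4-alkylphenyl back onto the alkyne is therefore expected to return the number toward the limit, with a 1.8-fold higher number from compound 3 to compound 4 (0.26 log units; within the scatter) as the estimated step. For compound 4 the expected value is 150000 nM, within 60000 nM to 400000 nM.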

Compound 4, half-maximal inhibitory concentration: > 100000 nM
Compound 4: a limit, no number; the forecaster's own chance of this, stated with the estimate: 75%; the middle value lies beyond the limit too.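

In this assay, compound 4 gives > 100000 nM, which is a limit of the assay and not a number. Going by these compounds alone, the step is an at least 1.2-fold higher number from compound 3 to compound 4 (0.08 log units; that floor lies within the scatter), so this floor alone does not show that the 4-butylphenyl group does worse than butyl; what is new is that a third 4-alkylphenyl compound now stands with compounds 1 and 2, while compound 3, with butyl on the triple-bonded carbon, still holds the only true number: the limit of > 100000 nM in this assay, at which 3 of the 4 values shown sit. The steps among compounds 1, 2 and 4 cannot be read, so the 4-methylphenyl, 4-butylphenyl and 4-pentylphenyl groups cannot be told apart here.

From the compounds shown here alone, how far past the limit compounds 1, 2 and 4 really lie stays open, and so does whether the ring or the chain on it matters more. Within the data shown here, also open is whether an unsubstituted phenyl, a longer chain such as octyl, or a chain carrying an amine on the triple-bonded carbon would give a true number, and whether that number would differ clearly from the one for compound 3.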